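The source may hold more compounds than are shown below. What is called first, only, known or untested is meant among the compounds shown, and "the series" means these compounds.

Compound 3 `CNCCSc1nc(NCc2ccc(-c3ccccn3)cc2)c2[nH]nc(C(C)C)c2n1` gives 56 nM in a functional assay on HT cells (Homo sapiens) for antiproliferative activity, read by fluorescence, with a stated time of 72 h (on this read-out higher numbers stand for weaker inhibition of growth and lower numbers for stronger inhibition of growth), and holds the lowest number of the three compounds measured. The step of a 1.9-fold lower number from compound 2 to compound 3 (0.27 log units; within the scatter) lies within the scatter, so compound 2 `CC(C)c1n[nH]c2c(NCc3ccc(-c4ccccn4)cc3)nc(SCCCN(C)C)nc12`, with 105 nM, cannot be separated from it. Compound 1 `CCC(O)CSc1nc(NCc2ccc(-c3ccccn3)cc2)c2[nH]nc(C(C)C)c2n1` gives 273 nM, and the step of a 4.9-fold lower number from compound 1 to compound 3 (0.69 log units; beyond the scatter) sets compound 1 clearly apart from compound 3.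

Compound 4 `CC(C)c1n[nH]c2c(NCc3ccc(-c4ccccn4)cc3)nc(SCC(O)CN3CCNCC3)nc12` differs from compound 3 by 1-hydroxy-2-(piperazin-1-yl)ethyl in place of (methylamino)methyl on a saturated chain carbon bound to a sulfur. Two of the measured steps bear on this change. The steps of a 2.6-fold lower number from compound 1 to compound 2 (0.41 log units; beyond the scatter) and a 4.9-fold lower number from compound 1 to compound 3 (0.69 log units; beyond the scatter) show that chains ending in an amine gave lower numbers in this assay than the 1-hydroxypropyl chain, and the step of a 1.9-fold lower number from compound 2 to compound 3 (0.27 log units; within the scatter) shows that exchanging one amine for another moved the number by no more than the scatter. The entering group keeps an amine, now within a six-membered ring, and adds a hydroxyl back to the chain, so the step is expected to be small: compound 4 is estimated to give a slightly higher number than compound 3, a 1.5-fold higher number from compound 3 to compound 4 (0.18 log units; within the scatter), a step expected to stay within the scatter. Compound 4 is therefore expected to give about 85 nM in this assay, with a range from 30 nM to 250 nM.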

Compound 4, concentration for 50% growth inhibition: 332 nM
Beside the measured number, compound 4's estimate is 3.9-fold (0.59 log units) below it, outside the stated range (above it).
By their numbers in this assay, from the lowest: compounds 3 and 2 (each within the scatter of the next); then compounds 1 and 4 (each within the scatter of the next).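

In this assay the steps of a 5.9-fold higher number from compound 3 to compound 4 (0.77 log units; beyond the scatter) and a 3.2-fold higher number from compound 2 to compound 4 (0.50 log units; beyond the scatter) show that, on this saturated chain carbon bound to a sulfur, an amine in the chain does not by itself keep the number low, since the 2-hydroxy-3-(piperazin-1-yl)propyl chain carries the piperazine ring and still stands clearly apart from both open-chain amines. The step of a 1.2-fold higher number from compound 1 to compound 4 (0.08 log units; within the scatter) places this chain level with the hydroxyl chain of compound 1, so compound 4 goes against the earlier reading that amine-ending chains give lower numbers than the 1-hydroxypropyl chain; among these four compounds, the two chains with a hydroxyl now stand together and the two without one stand together. Nothing given here accounts for this change.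

The compounds shown change the hydroxyl and the ring together, so it remains open which of the two goes with the higher number. A plain 3-(piperazin-1-yl)propyl chain and a 3-(dimethylamino)-2-hydroxypropyl chain would each separate them, and a morpholine in place of the piperazine would ask whether the second ring nitrogen matters.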